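The compounds below may be only part of what the source reports. "The series", "measured", "known", "first", "only" and "open" are said of these compounds alone.

In a functional assay on KG-1 cells (Homo sapiens) for cytotoxicity, read by luminescence and CellTiter-Glo, with a stated time of 3 days (a lower number here means a stronger inhibitor, a higher number a weaker inhibitor), compound 1 `N#Cc1cc(Cl)ccc1NC(=O)c1ccc2cccnc2c1O` gives 3540 nM. Compound 3 `O=C(Nc1ccc(C(F)(F)F)cc1)c1cc(Cl)c(-c2ccccc2)cc1O` gives 770 nM, a lower number by a margin beyond the scatter, which leaves compound 1 with the higher of the two numerical values. Compound 2 `N#Cc1ccc2nc(-c3ccccc3O)[nH]c2c1` reads > 10000 nM, and this is a limit of the assay, not a number. Compound 4 `O=C(Nc1ccc(Cl)cc1Cl)c1ccc2cccnc2c1O` keeps the core of compound 1 and alters one group: chloro in place of cyano on an aromatic carbon. Among the compounds with values here, no measured pair shows this change of chloro in place of cyano on an aromatic carbon. A modest move toward a lower number is expected in this assay, not far beyond the scatter. The expected size is a 2.4-fold lower number from compound 1 to compound 4 (0.37 log units; beyond the scatter). The estimate for compound 4 is 1500 nM, with an expected range of 400 nM to 6000 nM.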

Compound 4, half-maximal inhibitory concentration: 3560 nM
Estimate against measurement, compound 4: 2.4-fold (0.38 log units) below, within the range that was stated.
By their numbers in this assay, from the lowest: compound 3; then compounds 1 and 4 (each within the scatter of the next). At a limit, above all of these: compound 2.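

In this assay, the change of chloro in place of cyano on an aromatic carbon, ortho to a large group, gives a 1.0-fold higher number from compound 1 to compound 4 (0.00 log units; within the scatter) and so does not separate the two groups at this position on the shared core. This is the only pair shown that differs in one place, so the reading holds for this one exchange alone. Nothing measured here accounts for the two groups reading alike.

The compounds shown leave open whether an amine or a carboxylic acid at this position would read differently. They also leave open whether the same exchange on another core would stay within the scatter.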